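From cyclohexylmethyl to 1-carboxyethyl on the shared core

The source may hold more compounds than are shown below. What is called first, only, known or untested is meant among the compounds shown, and "the series" means these compounds.

Compound 1 `CCNC(=O)Nc1nc2cc(-c3cccnc3)c(=O)n(CC3CC3)c2s1`: 5000 nM
Compound 2 `CCNC(=O)Nc1nc2cc(-c3cccnc3)c(=O)n(CC3CCCCC3)c2s1`: 7000 nM

In a physicochemical assay for solubility, in phosphate buffer, at pH 7.4 (a higher number here means a more soluble compound, a lower number a less soluble compound), compound 1 and compound 2 lie within the usual scatter of each other. Compound 3 `CCNC(=O)Nc1nc2cc(-c3cccnc3)c(=O)n(C(C)C(=O)O)c2s1` carries 1-carboxyethyl in place of cyclohexylmethyl on an aromatic nitrogen. Going by the values given here, the only measured step, a 1.4-fold higher number from compound 1 to compound 2 (0.15 log units; within the scatter), exchanged cyclopropyl for cyclohexyl, so it is a weak guide, and no measured compound carries the entering group. A move to a higher number is still expected, with an expected size of a 7.1-fold higher number from compound 2 to compound 3 (0.85 log units; beyond the scatter). The estimate for compound 3 is 50000 nM, within an expected range of 10000 nM to 200000 nM.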

Compound 3, solubility: 7290000 nM
For compound 3 the middle estimate is 150-fold (2.16 log units) below the measured one, and the stated range ends below it.
By their numbers in this assay, from the lowest: compounds 1 and 2 (each within the scatter of the next); then compound 3.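

In this assay, swapping one group on the aromatic nitrogen gives a 1000-fold higher number from compound 2 to compound 3 (3.02 log units; beyond the scatter) and a 1500-fold higher number from compound 1 to compound 3 (3.16 log units; beyond the scatter). Compound 1 and compound 2 lie within the scatter of each other, yet these two steps show that this position can carry a very large change in the read-out once 1-carboxyethyl enters. Nothing shown gives a reason for steps of this size. The entering group adds oxygen and removes the ring in a single change, and the compounds shown do not separate these features. A methyl ester or a 2-hydroxyethyl chain at this nitrogen would be a different test of them.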